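Trading an Ethoxyphenyl Group for an Indole

The source may hold more compounds than are shown below. What is called first, only, known or untested is meant among the compounds shown, and "the series" means these compounds.

In a functional assay on SiHa cells (Homo sapiens) for antiproliferative activity, read by CCK-8 assay, with a stated time of 72 h (on this read-out lower numbers stand for stronger inhibition and higher numbers for weaker inhibition), compound 1 `COc1ccc(-c2cncnc2-c2cc(OC)c(OC)c(OC)c2)cc1` gives 2850 nM, while compound 2 `CCOc1ccc(-c2cncnc2-c2cc(OC)c(OC)c(OC)c2)cc1` gives 640 nM, the lower of the two numbers. Among the measured compounds shown here, the only measured step, a 4.5-fold lower number from compound 1 to compound 2 (0.65 log units; beyond the scatter), places a methyl in place of a hydrogen on the chain carbon bound to oxygen. Compound 3 `COc1cc(-c2ncncc2-c2ccc3cc[nH]c3c2)cc(OC)c1OC` has 1H-indol-6-yl in place of 4-ethoxyphenyl on an aromatic carbon. For the measured compounds named here, no measured compound carries this new group, so the evidence is thin. The step of a 4.5-fold lower number from compound 1 to compound 2 (0.65 log units; beyond the scatter) shows only that a small edit to the group now leaving can move the number beyond the scatter. A whole-group exchange could move it further, in either direction, but a modest drop is the tentative expectation. The estimated change is a 3.2-fold lower number from compound 2 to compound 3 (0.51 log units; beyond the scatter). For compound 3 the expected value is 200 nM, with an estimated range of 20 nM to 1500 nM.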

Compound 3, half-maximal inhibitory concentration: 2180 nM
The estimate for compound 3 lay 11-fold (1.04 log units) below the measured number; the whole stated range lies below it.
By their numbers in this assay, from the lowest: compound 2; then compounds 3 and 1 (each within the scatter of the next).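

In this assay, placing 1H-indol-6-yl instead of 4-ethoxyphenyl on this aromatic carbon, ortho to a large group, gives a 3.4-fold higher number from compound 2 to compound 3 (0.53 log units; beyond the scatter) and so shows that this position does not accept every group of the same heavy-atom count equally. Measured against the 4-methoxyphenyl compound, the exchange gives a 1.3-fold lower number from compound 1 to compound 3 (0.12 log units; within the scatter) and stays within the usual scatter, so here the indole matches 4-methoxyphenyl but not 4-ethoxyphenyl. No supporting measurement bears on why the number differs between these groups.

The compounds shown leave open whether a propoxy chain on the phenyl ring would take the number lower than the ethoxy chain does. They also leave open whether a methyl on the indole nitrogen would change the result for the indole.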